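Ester in place of benzyl ether on the saturated oxygen

The compounds below may be only part of what the source reports. "The series", "measured", "known", "first", "only" and "open" are said of these compounds alone.

Four compounds on one shared core are followed in a functional assay on MDA-MB-231 cells (Homo sapiens) for antiproliferative activity, read by MTT assay, with a stated time of 72 h; a higher number here means a weaker inhibitor, a lower number a stronger inhibitor. Compound 1 `CC1=CCC2C(CC[C@@]2(C)O)C(C)(C)C1CC[C@@H]1[C@@]2(C)CCC(=O)C(C)(C)O[C@@H]2CC[C@]1(C)O` gives > 50000 nM; this is the limit of > 50000 nM in this assay, at which 1 of the 3 values shown sits, and not a number. Compound 2 `CC1=CC[C@H]2[C@@H]1CC=C(C)[C@@H](CC[C@H]1[C@]3(C)CC[C@H](OC(=O)CCC(=O)O)C(C)(C)O[C@H]3CC[C@@]1(C)O)C2(C)C` gives 29600 nM. Compound 3 `CC1=CC[C@H]2[C@H](CC[C@]2(C)O)C(C)(C)[C@@H]1CC[C@H]1[C@]2(C)CC[C@H](OCc3ccccc3)C(C)(C)O[C@H]2CC[C@@]1(C)O` gives 29100 nM, a number that lies within the scatter of the number for compound 2, so no order between these two can be read. Going by the values given here, no pair of measured compounds differs in one place only, so no single step is available as a guide.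

Compound 4 `CC1=CC[C@H]2[C@H](CC[C@]2(C)O)C(C)(C)[C@@H]1CC[C@H]1[C@]2(C)CC[C@H](OC(=O)c3ccccc3Cl)C(C)(C)O[C@H]2CC[C@@]1(C)O` differs from compound 3 by (2-chlorophenyl)carbonyl in place of benzyl on an oxygen on a saturated carbon. With compound 2 and compound 3 close to each other despite carrying different groups on that oxygen, the step of a 1.2-fold lower number from compound 3 to compound 4 (0.07 log units; within the scatter) is expected to stay within the scatter. Compound 4 is estimated at 25000 nM, with a range from 10000 nM to 60000 nM.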

Compound 4, half-maximal inhibitory concentration: 24300 nM
For compound 4 the middle estimate is 1.0-fold (0.01 log units) above the measured one, and the stated range covers the measured number.
By their numbers in this assay, from the lowest: compounds 4, 3 and 2 (each within the scatter of the next). At a limit, above all of these: compound 1.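

In this assay, going by these compounds alone, (2-chlorophenyl)carbonyl in place of benzyl on an oxygen on a saturated carbon gives a 1.2-fold lower number from compound 3 to compound 4 (0.08 log units; within the scatter) and is the first change in one place that can be read. On the shared core, this position therefore takes an aromatic ester as well as a benzyl ether with no step beyond the scatter. Nothing measured here gives a cause for this step.

Going by these compounds, whether an amine or a long alkyl chain on this oxygen would give a step beyond the scatter remains open.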